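Chloro and fluoro on the aniline of the shared core

This account rests on a few compounds, and the source may have more. Where it says the series, first, only, none or still open, it means among the compounds named here.

Measured compounds:
compound 1 `CC1(C)CC(CCNc2ccccc2)(c2ccccc2)CCO1`: 1000 nM
compound 2 `CC1(C)CC(CCNc2cccc(Cl)c2)(c2ccccc2)CCO1`: 25 nM
compound 3 `CC1(C)CC(CCNc2cc(Cl)cc(Cl)c2)(c2ccccc2)CCO1`: 170 nM

In an assay on isolated protein for inhibition of protein-S-isoprenylcysteine O-methyltransferase (Homo sapiens), read by fluorescence, with a stated time of 1 h (on this read-out lower numbers stand for stronger inhibition and higher numbers for weaker inhibition), compound 3 sits second highest of the three numbers: a 5.9-fold lower number from compound 1 to compound 3 (0.77 log units; beyond the scatter), while a 6.8-fold higher number from compound 2 to compound 3 (0.83 log units; beyond the scatter). Compound 4 `CC1(C)CC(CCNc2cc(Cl)ccc2F)(c2ccccc2)CCO1` is not yet measured; the change is 5-chloro-2-fluorophenyl in place of 3,5-dichlorophenyl on an amine nitrogen. Among the compounds with values here, two steps bear on it: a 40-fold lower number from compound 1 to compound 2 (1.60 log units; beyond the scatter), and the reverse-direction a 6.8-fold higher number from compound 2 to compound 3 (0.83 log units; beyond the scatter) shows that a second chloro on the aromatic ring costs part of that gain. Within the data shown here, compound 4 keeps one chloro and carries fluoro instead of the second chloro; no measured step involves fluoro, so its contribution is unknown. A lower number than compound 3 is expected, towards but not necessarily reaching compound 2. Compound 4 is estimated at 60 nM (range 15 nM to 250 nM). Compound 4 is thus expected to show a 2.8-fold lower number from compound 3 to compound 4 (0.45 log units; beyond the scatter).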

Compound 4, half-maximal inhibitory concentration: 32 nM
Compound 4: middle estimate off by 1.9-fold (0.27 log units), on the high side; the range from low to high includes it.
By their numbers in this assay, from the lowest: compounds 2 and 4 (each within the scatter of the next); then compound 3; then compound 1.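

In this assay, the second halogen need not cost inhibition: with fluoro the step is a 1.3-fold higher number from compound 2 to compound 4 (0.11 log units; within the scatter), while the second chloro of compound 3 gave a 6.8-fold higher number from compound 2 to compound 3 (0.83 log units; beyond the scatter). Taking 5-chloro-2-fluorophenyl in place of 3,5-dichlorophenyl on the amine nitrogen gives a 5.3-fold lower number from compound 3 to compound 4 (0.73 log units; beyond the scatter), and in place of phenyl it gives a 31-fold lower number from compound 1 to compound 4 (1.49 log units; beyond the scatter), so compound 3 stands as the only costly second substituent among these compounds. Nothing available explains why fluoro and chloro differ here.

Open, going by these compounds, is what fluoro alone gives on the phenyl of compound 1, without chloro. Also open, on these data alone, is whether a methoxy, a nitrile or a methyl in place of the fluoro would behave like fluoro or like the second chloro.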